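The source may report more compounds than this note shows. Statements on the series, on what has been measured and on what is new or still open speak of the compounds shown alone.

Compound 2, `C(#Cc1ncnc2c1ncn2C1CCOCC1)c1ccccc1`, gives 100% in a functional assay on K562 cells (Homo sapiens) for inhibition, read by thymidine incorporation, with a stated time of 48 h, tested at 10 ug/mL (a higher number here means more inhibition at the concentration tested (going by the name of the read-out), a lower number less inhibition), the same number at the digits shown as compound 1, `C(#Cc1[nH]cnc2ncnc1-2)c1ccccc1`, which gives 100%; compound 3, `Clc1nc2c(C#Cc3ccccc3)ncnc2n1C1CCOCC1`, gives 85%. Among the compounds with values here, the one measured step, a number 15 percentage points lower from compound 2 to compound 3 (beyond the scatter), swaps a substituent on an aromatic carbon. Compound 4, `C(#Cc1ncnc2c1ncn2Cc1ccccc1)c1ccccc1`, differs from compound 2 at another place: benzyl in place of oxan-4-yl on an aromatic nitrogen. Within the data shown here, no measured step changes the group on that ring nitrogen, so the chloro step gives no direct guide; the values of compound 1 and compound 2 show no difference between hydrogen and oxan-4-yl there. Compound 4 is therefore expected to give about 93%, estimated between 75% and 100%. The expected step is a number 7 percentage points lower from compound 2 to compound 4 (within the scatter).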

Compound 4, a percentage reported as inhibition, at one concentration (the size of the read-out at that concentration, not a potency): 98%
Compound 4: middle estimate off by 5 percentage points, on the low side; low and high end bracket the measured number.
By their numbers in this assay, from the lowest: compound 3; then compounds 4, 1 and 2 (each within the scatter of the next).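

The step of a number 2 percentage points lower from compound 2 to compound 4 (within the scatter) in this assay shows that this ring nitrogen can carry benzyl, with its aromatic ring of carbon only, as well as oxan-4-yl, a non-aromatic ring containing oxygen. Both compounds sit close to the top of a percentage scale at a single concentration, so this read-out cannot show whether either has the stronger effect at that concentration. No evidence is available to explain the result. Still open, on these data alone, is whether an amine, a carboxylic acid or a longer alkyl chain on that nitrogen would keep inhibition this high.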